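The source may hold more compounds than are shown below. What is called first, only, known or untested is meant among the compounds shown, and "the series" means these compounds.

Measured so far in a functional assay for inhibition, with a stated time of 30 min; a lower number here means a stronger inhibitor, a higher number a weaker inhibitor:
- compound 1 `c1ccc(-c2[nH]c3ccccc3c2C2CC(c3cccs3)=NO2)cc1` gives 118 ug/mL
- compound 2 `c1ccc(-c2[nH]c3ccccc3c2C2CC(c3ccncc3)=NO2)cc1` gives 59.9 ug/mL

Compound 2 at 59.9 ug/mL lies within the scatter of compound 1, so neither stands apart on these numbers. Within the data shown here, compound 3 `c1ccc(-c2[nH]c3ccccc3c2C2CC(c3cccnc3)=NO2)cc1` has pyridin-3-yl in place of pyridin-4-yl on a carbon with a double bond to nitrogen, the same place as the only measured step. That step, a 2.0-fold lower number from compound 1 to compound 2 (0.29 log units; within the scatter), stayed within the scatter, so this assay is expected to show no shift beyond the scatter. The estimate is a 1.2-fold higher number from compound 2 to compound 3 (0.07 log units; within the scatter) as the expected step. Compound 3 is estimated at 70 ug/mL with an expected range from 30 ug/mL to 150 ug/mL for this measurement.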

Compound 3, half-maximal inhibitory concentration: 60.7 ug/mL
For compound 3 the middle estimate is 1.2-fold (0.06 log units) above the measured one; the range from low to high includes it.
By their numbers in this assay, from the lowest: compounds 2, 3 and 1 (each within the scatter of the next).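

In this assay pyridin-3-yl in place of pyridin-4-yl on the carbon with a double bond to nitrogen leaves the number within the scatter (a 1.0-fold higher number from compound 2 to compound 3 (0.01 log units; within the scatter)), so the two groups cannot be told apart here. Pyridin-3-yl in place of thiophen-2-yl also stays within the scatter (a 1.9-fold lower number from compound 1 to compound 3 (0.29 log units; within the scatter)), so compounds 1, 2 and 3 do not separate at this position. Nothing further is available to explain these numbers. On these data alone, whether a non-aromatic group here, such as an amine or a carboxylic acid, would move the number beyond the scatter remains open.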